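A few compounds are considered here, and "the series" means these few. Any claim that something is new, unique, unknown or untested is made for them only; others in the source may bear on it.

Three compounds have been measured:
compound 1 `N/C(=N\NC(=S)N1CCOCC1)c1ccccn1` gives 87.2%
compound 2 `N/C(=N\NC(=S)N1CCN(c2ccccn2)CC1)c1ccc(F)cn1` gives 83%
compound 3 `N/C(=N\NC(=S)N1CCCC1)c1ccc(F)cn1` gives 85.4%

All three numbers come from a functional assay on HeLa cells (Homo sapiens) for cytotoxicity, read by MTT assay, with a stated time of 72 h, tested at 100 uM; a higher number here means more inhibition of growth at the concentration tested, a lower number less inhibition of growth. Compound 1 stands level with the other two: its gap to compound 3 and its gap to compound 2 both lie within the scatter, so no order among the three can be read. Compound 4 `N/C(=N\NC(=S)N1CCSCC1)c1ccccn1` is not yet measured. It differs from compound 1 in one place: thiomorpholin-4-yl in place of morpholin-4-yl on a thiocarbonyl carbon. For the measured compounds named here, no measured pair differs in a single place, so no step size can be taken from the data; the other two compounds, with quite different groups, sit at much the same level as compound 1. The expected step, a number 1.2 percentage points lower from compound 1 to compound 4 (within the scatter), is therefore none beyond the scatter. Compound 4 is estimated at 86%, within a range from 76% to 94%.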

Compound 4, percent growth inhibition at one concentration: 88.7%
Beside the measured number, compound 4's estimate is 2.7 percentage points below it; measured number inside the range.
By their numbers in this assay, from the lowest: compounds 2, 3, 1 and 4 (each within the scatter of the next).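

Swapping morpholin-4-yl for thiomorpholin-4-yl on a thiocarbonyl carbon gives the first step that can be read in this assay, a number 1.5 percentage points higher from compound 1 to compound 4 (within the scatter) and so leaves the number level. Oxygen and sulfur in this ring are therefore not told apart by this measurement at this position. Nothing available accounts for this result.

Still open, as far as these compounds go, is whether piperidin-1-yl, with a ring carbon in place of that oxygen or sulfur, or an open-chain diethylamino group would also stay level on the core of compound 1. From the compounds shown here alone, a step at lower test concentrations also remains unknown.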